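Dimethylsulfamoyl step in a nitrobenzenesulfonamide series

The source may report more compounds than this note shows. Statements on the series, on what has been measured and on what is new or still open speak of the compounds shown alone.

Three compounds of one core have been run in an assay on HEK293 cells for inhibition of solute carrier family 12 member 2 (Homo sapiens), read by fluorescence, with a stated time of 30 min, tested at 100 uM; on this read-out higher numbers stand for a stronger effect at the one concentration tested and lower numbers for a weaker effect. Compound 1 `CCCCNc1ccc([N+](=O)[O-])cc1S(N)(=O)=O` gives 4.7%. Compound 2 `CCCCCCNc1ccc([N+](=O)[O-])cc1S(N)(=O)=O` gives 3.8%; the step of a number 0.9 percentage points lower from compound 1 to compound 2 (within the scatter) sits within the scatter. Compound 3 `CCCCNc1ccc([N+](=O)[O-])cc1S(=O)(=O)NC` gives 13.3%; the step of a number 8.6 percentage points higher from compound 1 to compound 3 (within the scatter) also sits within the scatter. On the numbers shown compound 3 holds the top figure of the three, yet compound 1 lies within the scatter of it and the value of compound 2, set beside the value of compound 3, shows a gap of the same order, so no compound can be called more active than another.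

Compound 4 `CCCCNc1ccc([N+](=O)[O-])cc1S(=O)(=O)N(C)C` is the next member. It differs from compound 3 by methyl in place of hydrogen on a sulfonamide nitrogen. Within the data shown here, the one measured step that bears on this change is the earlier methylation of the same nitrogen, a number 8.6 percentage points higher from compound 1 to compound 3 (within the scatter), which did not rise above the scatter. The chain step a number 0.9 percentage points lower from compound 1 to compound 2 (within the scatter) touches another part of the molecule and was flat as well. Among the measured compounds shown here, the series so far therefore gives no ground for a step beyond the scatter in this assay in either direction, and the second methyl on the sulfonamide nitrogen is expected to leave the read-out near that of compound 3.

Compound 4 is accordingly estimated at 13%, with a range of 2% to 26%, meaning an expected step of a number 0.3 percentage points lower from compound 3 to compound 4 (within the scatter).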

Compound 4, a percentage reported as inhibition, at one concentration (the size of the read-out at that concentration, not a potency): 15.2%
Compound 4: the middle estimate sits 2.2 percentage points below what was measured; low and high end bracket the measured number.
By their numbers in this assay, from the lowest: compounds 2, 1, 3 and 4 (each within the scatter of the next, the first and the last beyond it).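

In this assay the second methyl on the sulfonamide nitrogen (step: a number 1.9 percentage points higher from compound 3 to compound 4 (within the scatter)) does not separate the methylsulfamoyl and dimethylsulfamoyl forms, so this single methylation alone cannot be read as a change. Taken together, however, the two methyls on this nitrogen give the first step in the series to pass the scatter, the modest a number 10.5 percentage points higher from compound 1 to compound 4 (beyond the scatter), even though the first methylation on its own stayed within the scatter (step: a number 8.6 percentage points higher from compound 1 to compound 3 (within the scatter)), so at this position a difference appears only when the unsubstituted sulfonamide is compared with the dimethylsulfamoyl form. No supporting data are available to explain this difference.

Still open, on these data alone, is whether larger groups on the same nitrogen, such as diethyl or a pyrrolidine ring, would carry the read-out further in this assay, and whether the dimethylsulfamoyl step would hold on the longer chain of compound 2. As far as these compounds go, all of these figures are read-outs at one concentration, so they show only the size of the effect at that concentration, and whether a step of this modest size would hold up across further members remains open.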